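Phenyl in Place of Allyl on a Selenocyanate Carbamate

The compounds below may be only part of what the source reports. "The series", "measured", "known", "first", "only" and "open" are said of these compounds alone.

Compound 1, `C=CCOC(=O)Nc1ccc([Se]C#N)cc1`: 9200 nM
Compound 2, `O=C(Nc1ccc([Se][Se]c2ccc(NC(=O)Oc3ccccc3)cc2)cc1)Oc1ccccc1`: 22400 nM
Compound 3, `CCCCOC(=O)Nc1ccc([Se][Se]c2ccc(NC(=O)OCCCC)cc2)cc1`: 16700 nM

These three compounds were tested in a functional assay on CCRF-CEM cells (Homo sapiens) for cytotoxicity, read by MTT assay, with a stated time of 72 h; on this read-out lower numbers stand for stronger inhibition of growth and higher numbers for weaker inhibition of growth. Compound 1 has the lowest of the three numbers; its gap to compound 3 lies within the scatter, while compound 2 gives a higher number than compound 1, a gap beyond the scatter. Compound 4, `N#C[Se]c1ccc(NC(=O)Oc2ccccc2)cc1`, has not yet been measured. It differs from compound 1 in one place: phenyl in place of allyl on an oxygen next to a carbonyl group. Among the measured compounds, compound 2 and compound 3 also carry different groups on that oxygen, yet their numbers lie within the scatter of each other. For the measured compounds named here, no measured pair shows this exact change, so the expected step of a 1.2-fold higher number from compound 1 to compound 4 (0.08 log units; within the scatter) is small, none beyond the scatter. Compound 4 is therefore estimated at 11000 nM, with a range from 4000 nM to 30000 nM.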

Compound 4, concentration for 50% growth inhibition: 22900 nM
The estimate for compound 4 lay 2.1-fold (0.32 log units) below the measured number, and the stated range covers the measured number.
By their numbers in this assay, from the lowest: compounds 1, 3, 2 and 4 (each within the scatter of the next, the first and the last beyond it).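

In this assay phenyl in place of allyl on this oxygen gives a 2.5-fold higher number from compound 1 to compound 4 (0.40 log units; beyond the scatter) and so weakens inhibition of growth. For the compounds shown here, no earlier pair differed in this one place, so this is the first direct sign that the group here can change the number, though it rests on a single pair. Nothing available explains the step. Still open, from the compounds shown here alone, is whether the ring itself or the loss of the allyl double bond matters: propyl or benzyl on this oxygen would help separate the two.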